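The source may hold more compounds than are shown below. What is called first, only, known or untested is meant among the compounds shown, and "the series" means these compounds.

Among the measured compounds shown here, in a functional assay on HeLa cells (Homo sapiens) for cytotoxicity, read by ELISA, with a stated time of 2 days (on this read-out higher numbers stand for weaker inhibition and lower numbers for stronger inhibition), three compounds built on one shared core have numbers so far. Compound 1 `Oc1cccc(-c2cc(-c3ccccc3)nc(-c3ccccc3)c2)c1` carries a phenyl group on the aromatic carbon that varies and gives 15100 nM as its value. Compound 2 `Oc1cccc(-c2cc(-c3ccccc3)nc(-c3cccs3)c2)c1` carries thiophen-2-yl there and gives 15300 nM as its value. Compound 3 `Oc1cccc(-c2cc(-c3ccccc3)nc(-c3ccsc3)c2)c1` carries thiophen-3-yl there and gives 14900 nM as its value, which puts it level with the other two within the usual scatter of such measurements.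

The next structure, compound 4 `Oc1cccc(-c2cc(-c3ccccc3)nc(-c3ccco3)c2)c1`, keeps the core of compound 3 and has furan-2-yl in place of thiophen-3-yl on an aromatic carbon, a change that reads furan-2-yl in place of thiophen-3-yl on an aromatic carbon when counted out.

For the measured compounds named here, three measured steps bear on this change, all at that same carbon: a 1.0-fold higher number from compound 1 to compound 2 (0.01 log units; within the scatter) and a 1.0-fold lower number from compound 1 to compound 3 (0.01 log units; within the scatter) and also a 1.0-fold lower number from compound 2 to compound 3 (0.01 log units; within the scatter) are each within the scatter. Going by the values given here, no furan-2-yl compound has been measured yet, so these steps are a guide and not proof. Hence no step beyond the scatter is expected in this assay here, and the estimated change is a 1.0-fold higher number from compound 3 to compound 4 (0.00 log units; within the scatter) in size. For compound 4 the expected value is 15000 nM with an estimated range from 8000 nM to 27000 nM in this read-out.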

Compound 4, half-maximal inhibitory concentration: 10900 nM
For compound 4 the middle estimate is 1.4-fold (0.14 log units) above the measured one; the measured number falls inside the stated range.
By their numbers in this assay, from the lowest: compounds 4, 3, 1 and 2 (each within the scatter of the next).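

In this assay the furan-2-yl group of compound 4 joins the three groups already seen at this carbon, and all its steps stay within the scatter (a 1.4-fold lower number from compound 3 to compound 4 (0.14 log units; within the scatter)) and (a 1.4-fold lower number from compound 2 to compound 4 (0.15 log units; within the scatter)) and (a 1.4-fold lower number from compound 1 to compound 4 (0.14 log units; within the scatter)). The earlier compounds shown here showed this flat picture only for phenyl and the two thiophenes, which left sulfur as the only hetero atom among the five-membered rings, whereas compound 4 extends it to a ring with oxygen in place of sulfur, so at this position next to the ring nitrogen all four aromatic rings give values that cannot be told apart. Nothing measured here explains why these groups read alike.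

As far as these compounds go, all four groups are uncharged aromatic rings of similar size, so it remains open whether this carbon stays as indifferent to a non-aromatic group such as an amine, a carboxylic acid or a longer chain. The compounds shown also leave open how the values respond to changes in the 3-hydroxyphenyl and phenyl groups, since these stay the same throughout.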